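The source may report more compounds than this note shows. Statements on the series, on what has been measured and on what is new or still open speak of the compounds shown alone.

Compound 1 `C=C1[C@@H](OC(C)=O)C[C@@H]2[C@](C)(COC=O)[C@H](OC(C)=O)CC[C@@]2(C)[C@@H]1C[C@@H](Nc1ccc(OC)cc1)C1=CCOC1=O` and compound 3 `C=C1[C@@H](OC(C)=O)C[C@@H]2[C@](C)(COC=O)[C@H](OC(C)=O)CC[C@@]2(C)[C@@H]1C[C@@H](Nc1ccc(C(=O)O)cc1)C1=CCOC1=O` share one core and differ by methoxy in place of carboxy on an aromatic carbon. In a functional assay on A549 cells (Homo sapiens) for cytotoxicity, read by sulforhodamine B assay (a lower number here means a stronger inhibitor, a higher number a weaker inhibitor), compound 1 gives 28900 nM. Compound 3 reaches only a limit of this assay, > 50000 nM. That value sits at the limit of > 50000 nM in this assay, at which 1 of the 3 values shown sits, so the step is an at least 1.7-fold lower number from compound 3 to compound 1 (0.23 log units; that floor lies within the scatter). Compound 2 `C=C1[C@@H](OC(C)=O)C[C@@H]2[C@](C)(CO[Si](C)(C)C(C)(C)C)[C@H](OC(C)=O)CC[C@@]2(C)[C@@H]1C[C@@H](Nc1ccc(C(=O)O)cc1)C1=CCOC1=O` differs from compound 3 by a group of 7 heavy atoms (6 carbon, 1 silicon; no ring) in place of a group of 2 heavy atoms (1 carbon, 1 oxygen; no ring), on an oxygen on a saturated carbon, and in this assay compound 2 gives 4210 nM, the step being an at least 11-fold higher number from compound 2 to compound 3 (1.07 log units; beyond the scatter). Compound 4 `C=C1[C@@H](OC(C)=O)C[C@@H]2[C@](C)(CO[Si](C)(C)C(C)(C)C)[C@H](OC(C)=O)CC[C@@]2(C)[C@@H]1C[C@@H](Nc1ccc(OC)cc1)C1=CCOC1=O` differs from compound 2 by methoxy in place of carboxy on an aromatic carbon, the same change as that made from compound 3 to compound 1, here on the core of compound 2. For compound 4 the expected step is a 1.7-fold lower number from compound 2 to compound 4 (0.23 log units; within the scatter), resting on the earlier step of an at least 1.7-fold lower number from compound 3 to compound 1 (0.23 log units; that floor lies within the scatter), whose floor lies within the scatter. Compound 4 is therefore estimated at 2500 nM, within 800 nM to 8000 nM.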

Compound 4, half-maximal inhibitory concentration: 4810 nM
The estimate for compound 4 lay 1.9-fold (0.28 log units) below the measured number; the measured number falls inside the stated range.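

On the core carrying the group of 7 heavy atoms, methoxy in place of carboxy gives in this assay a 1.1-fold higher number from compound 2 to compound 4 (0.06 log units; within the scatter), and the earlier step on the other core cannot be set firmly against it: the same change on two cores in this assay, an at least 1.7-fold lower number (0.23 log units; that floor lies within the scatter) from compound 3 to compound 1 and a 1.1-fold higher number (0.06 log units; within the scatter) from compound 2 to compound 4; the limit leaves it open whether they differ. The exchange on the oxygen, read on the methoxy pair, gives a 6.0-fold lower number from compound 1 to compound 4 (0.78 log units; beyond the scatter), and it points the same way on both cores: the same change on two cores in this assay, an at least 11-fold higher number (1.07 log units; beyond the scatter) from compound 2 to compound 3 and a 6.0-fold higher number (0.78 log units; beyond the scatter) from compound 4 to compound 1; the limit leaves it open whether they differ. The series thus shows no sign that the aromatic change behaves differently on the two cores, but it does not show that its size carries over unchanged.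

The compounds shown leave open how an amine or a longer alkoxy chain in place of methoxy would read in this assay. They also leave open how a free alcohol on that oxygen would read.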